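Dimethylsulfamoyl in place of cyclobutylsulfonyl on the shared core

The compounds below may be only part of what the source reports. "The series", "measured", "known", "first", "only" and "open" are said of these compounds alone.

Compound 2 `O=C([C@@H]1CCCN(S(=O)(=O)c2ccc(S(=O)(=O)C3CCC3)cc2)C1)N1CCC(F)(F)CC1` stands lowest of the three compounds measured in a functional assay on MIA PaCa-2 cells (Homo sapiens) for inhibition, read by MTT assay, with a stated time of 7 days (a lower number here means a stronger inhibitor, a higher number a weaker inhibitor), where compound 2 gives 9 nM. Among the compounds with values here, compound 1 `CCN(CC)S(=O)(=O)c1ccc(S(=O)(=O)N2CCC[C@@H](C(=O)N[C@H]3CC[C@H](OC)CC3)C2)cc1` gives 1350 nM and compound 3 `CCN(CC)S(=O)(=O)c1ccc(S(=O)(=O)N2CCC[C@@H](C(=O)NC3CCOCC3)C2)cc1` gives 3770 nM; the only single-site step among the measured compounds, a 2.8-fold higher number from compound 1 to compound 3 (0.45 log units; beyond the scatter), sits on the amide nitrogen, not at the sulfonyl sulfur. Compound 4 `CN(C)S(=O)(=O)c1ccc(S(=O)(=O)N2CCC[C@@H](C(=O)N3CCC(F)(F)CC3)C2)cc1` differs from compound 2 by dimethylamino in place of cyclobutyl on a sulfonyl sulfur. Within the data shown here, no measured step isolates that sulfonyl substituent: compounds 1 and 3 carry a diethylamino group there but also a different amide, so their gap to compound 2 cannot be apportioned. The expectation is therefore that the step of a 2.2-fold higher number from compound 2 to compound 4 (0.35 log units; beyond the scatter) stays small, with some risk of a higher number. Compound 4 is estimated at 20 nM, in a range from 5 nM to 80 nM.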

Compound 4, half-maximal inhibitory concentration: 118 nM
The estimate for compound 4 lay 5.9-fold (0.77 log units) below the measured number, outside the stated range (above it).
By their numbers in this assay, from the lowest: compound 2; then compound 4; then compound 1; then compound 3.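

Within the data shown here, with the amide held fixed, this is the first measured step at this position, and in this assay dimethylamino in place of cyclobutyl on a sulfonyl sulfur gives a 13-fold higher number from compound 2 to compound 4 (1.12 log units; beyond the scatter). Among these compounds, the substituent on that sulfur therefore counts for a large share of the number on its own, a share that the earlier compounds could not separate from the amide. Nothing measured here explains the change.

The compounds shown leave open whether the ring or the attached nitrogen matters more. Pyrrolidin-1-yl, which keeps a ring on nitrogen, and isopropyl, an open carbon group, would separate the two on the same sulfur.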